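From phenyl to naphthalen-2-yl on the shared core

The source may hold more compounds than are shown below. What is called first, only, known or untested is meant among the compounds shown, and "the series" means these compounds.

Compound 1 `COc1ccc(/C=C/c2cc(OC)c(OC)c(OC)c2-c2ccc(F)c(C)c2)cc1`: 17000 nM
Compound 2 `C=C(c1ccc(OC)cc1)c1cc(OC)c(OC)c(OC)c1-c1ccc(OC)cc1`: 72000 nM
Compound 3 `C=C(c1ccc(OC)cc1)c1cc(OC)c(OC)c(OC)c1-c1ccccc1`: 11000 nM

All three values come from a functional assay on HeLa cells (Homo sapiens) for cytotoxicity, read by MTT assay, with a stated time of 48 h; a lower number here means a stronger inhibitor, a higher number a weaker inhibitor. Compound 3 and compound 1 lie within the scatter of each other, while compound 2 stands clearly apart, as a 6.5-fold lower number from compound 2 to compound 3 (0.82 log units; beyond the scatter) shows. Compound 4 `C=C(c1ccc(OC)cc1)c1cc(OC)c(OC)c(OC)c1-c1ccc2ccccc2c1` has not yet been measured. It differs from compound 3 by naphthalen-2-yl in place of phenyl on an aromatic carbon. For the measured compounds named here, only one measured step touches this same group: a 6.5-fold lower number from compound 2 to compound 3 (0.82 log units; beyond the scatter), hydrogen in place of methoxy. Read in reverse, it links added bulk on that phenyl to a higher number, so a modest rise is expected, on thin evidence. The expected change is a 2.2-fold higher number from compound 3 to compound 4 (0.34 log units; beyond the scatter). Compound 4 is estimated at 24000 nM, with an expected range from 8000 nM to 70000 nM.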

Compound 4, half-maximal inhibitory concentration: 35000 nM
Estimate against measurement, compound 4: 1.5-fold (0.16 log units) below; measured number inside the range.
By their numbers in this assay, from the lowest: compounds 3 and 1 (each within the scatter of the next); then compound 4; then compound 2.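

In this assay the exchange of phenyl for naphthalen-2-yl gives a 3.2-fold higher number from compound 3 to compound 4 (0.50 log units; beyond the scatter) and so shows that a group of carbon only, carrying no methoxy, also goes with a higher number than phenyl at this position. Naphthalen-2-yl still stands lower than 4-methoxyphenyl, with a 2.1-fold lower number from compound 2 to compound 4 (0.31 log units; beyond the scatter) on that exchange, so these two groups do not raise the number equally. On these data alone, whether an amine or a carboxylic acid on this phenyl would lower or raise the number stays open. Nothing shown here accounts for these steps.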